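This account rests on a few compounds, and the source may have more. Where it says the series, first, only, none or still open, it means among the compounds named here.

Three related compounds have been read in a functional assay on MKN-45 cells (Homo sapiens) for inhibition, read by CCK-8 assay, with a stated time of 24 h; a higher number here means a weaker inhibitor, a lower number a stronger inhibitor. Compound 1 `O=C1Nc2ccccc2/C1=C/c1ccc(-c2cn(-c3ccc(Cl)c(C(F)(F)F)c3)nn2)cc1` gives 8890 nM, and compound 2 `Cc1cccc(-n2cc(-c3ccc(/C=C4\C(=O)Nc5ccc(F)cc54)cc3)nn2)c1` gives 6810 nM. Compound 3 `O=C1Nc2ccc(F)cc2/C1=C/c1ccc(-c2cn(-c3ccc(F)cc3)nn2)cc1` gives > 20000 nM, which is a limit of the assay and not a number, so its place on the scale is known only as a limit.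

Compound 4 `O=C1Nc2ccc(F)cc2/C1=C/c1ccc(-c2cn(-c3ccc(Cl)c(C(F)(F)F)c3)nn2)cc1` has not yet been measured. It differs from compound 3 by 4-chloro-3-(trifluoromethyl)phenyl in place of 4-fluorophenyl on an aromatic nitrogen. In words, 4-chloro-3-(trifluoromethyl)phenyl stands in place of 4-fluorophenyl on an aromatic nitrogen.

One measured step involves the leaving group: an at least 2.9-fold higher number from compound 2 to compound 3 (0.46 log units; beyond the scatter), when 4-fluorophenyl replaced 3-methylphenyl on that nitrogen. The entering group is already present in compound 1, on a core of its own, and compound 1 gives 8890 nM. Compound 4 shares its core with compound 2, and compound 2 gives 6810 nM.

On these readings, a clear move towards a lower number, and so a stronger inhibitor, is expected in this assay, although its true size is uncertain without a number for the starting point. The estimated change is an at least 2.6-fold lower number from compound 3 to compound 4 (0.42 log units; beyond the scatter). For compound 4 the expected value is 7500 nM, with an estimated range from 3000 nM to 19000 nM.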

Compound 4, half-maximal inhibitory concentration: > 20000 nM
Compound 4 was reported as a limit; the forecaster's own chance of this, stated with the estimate: 15%; middle value at least 2.6-fold (0.42 log units) from the limit.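

In this assay, on the core that compound 2 shares with compound 4, 4-chloro-3-(trifluoromethyl)phenyl on the aromatic nitrogen gives an at least 2.9-fold higher number from compound 2 to compound 4 (0.46 log units; beyond the scatter), the same direction that 4-fluorophenyl took, so neither group in this position matches 3-methylphenyl on this core. The group that read below the limit on the core of compound 1 does not keep that reading here, for fluoro in place of hydrogen on an aromatic carbon gives an at least 2.2-fold higher number from compound 1 to compound 4 (0.35 log units; beyond the scatter). The step between compound 3 and compound 4 cannot be read, because both are reported only as a limit of the assay and not as a number: the limit of > 20000 nM in this assay, at which 2 of the 4 values shown sit.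

Going by these compounds, it stays open how far 4-fluorophenyl and 4-chloro-3-(trifluoromethyl)phenyl lie from each other on this core, and whether fluoro in place of hydrogen would move the number in the same way with 3-methylphenyl on the nitrogen. On these data alone, it is also open whether an amine or a carboxylic acid on the phenyl ring at this nitrogen would bring the shared core to a lower number than compound 2 gives.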